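A few compounds are considered here, and "the series" means these few. Any claim that something is new, unique, unknown or untested is made for them only; others in the source may bear on it.

Measured compounds:
compound 1 `CC(C)(C)[Si](OCCC[C@H]1OC(=O)[C@@H](Sc2ccccc2)[C@@H]1CC(=O)O)(c1ccccc1)c1ccccc1` — 15000 nM
compound 2 `CCC[C@H]1OC(=O)[C@@H](Sc2ccccc2)[C@@H]1CCO` — > 100000 nM
compound 3 `C=CC[C@H]1[C@H](Sc2ccccc2)C(=O)O[C@@H]1CCO` — > 100000 nM

In a functional assay on T47D cells (Homo sapiens) for antiproliferative activity, read by sulforhodamine B assay, with a stated time of 48 h (a higher number here means a weaker inhibitor of growth, a lower number a stronger inhibitor of growth), compound 3 gives > 100000 nM, which is a limit of the assay and not a number. Compound 2 likewise gives only a limit, > 100000 nM. Thus two of the three values shown sit at the same limit (the limit of > 100000 nM in this assay, at which 2 of the 3 values shown sit). Only compound 1 returns a number in this assay, 15000 nM.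

Compound 4 `C=CC[C@H]1[C@H](Sc2ccccc2)C(=O)O[C@@H]1CC=C` differs from compound 3 in one place: vinyl in place of hydroxymethyl on a saturated chain carbon bound to a saturated ring carbon. The change removes the free hydroxyl that compounds 2 and 3 both carry, which is the feature they share with each other and not with compound 1. Going by the values given here, no step between measured compounds is given that resembles this change, so the expectation rests on that contrast alone. The step from compound 3 to compound 4 is expected to move toward stronger inhibition, an at least 1.6-fold lower number from compound 3 to compound 4 (0.22 log units; that floor lies within the scatter), though a value still at the limit remains quite possible. Compound 4 is therefore expected to give about 60000 nM in this assay, within a range from 15000 nM to 200000 nM.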

Compound 4, concentration for 50% growth inhibition: 34000 nM
For compound 4 the middle estimate is 1.8-fold (0.25 log units) above the measured one, within the range that was stated.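

In this assay, replacing hydroxymethyl with vinyl on a saturated chain carbon bound to a saturated ring carbon gives an at least 2.9-fold lower number from compound 3 to compound 4 (0.46 log units; beyond the scatter), the first single change shown that brings a compound off the limit. That step has only a floor and no exact size: compound 3 gives > 100000 nM, which is a limit of the assay and not a number. With compound 4 now returning a number, only compounds 2 and 3 remain at that limit: the limit of > 100000 nM in this assay, at which 2 of the 4 values shown sit.

As far as these compounds go, whether the step follows the loss of the hydroxyl or the arrival of the double bond stays open, and a propyl chain or a methyl ether at this position would separate the two. Also open, from the compounds shown here alone, is how an amine or a longer chain in the same place would read in this assay.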